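This account rests on a few compounds, and the source may have more. Where it says the series, first, only, none or still open, it means among the compounds named here.

Compound 2 `C=C1C[C@]23C[C@@]1(O)CC[C@H]2c1ccc(OS(=O)(=O)c2ccc(C)cc2)c(C)c1[C@@H]3Cn1cc(-c2ccc(C)cc2)nn1` is the starting point. In a functional assay on HL-60 cells (Homo sapiens) for cytotoxicity, read by MTT assay, with a stated time of 4 days (on this read-out lower numbers stand for stronger inhibition and higher numbers for weaker inhibition), compound 2 gives > 20000 nM, which is a limit of the assay rather than a number. Two measured relatives share most of its structure. Compound 1 `C=C1C[C@]23C[C@@]1(O)CC[C@H]2c1ccc(O)c(C)c1[C@@H]3Cn1cc(-c2ccccn2)nn1` carries hydrogen where compound 2 carries the (4-methylphenyl)sulfonyl group, and pyridin-2-yl where compound 2 carries 4-methylphenyl. In this assay compound 1 gives > 20000 nM, again a limit. Compound 3 `C=C1C[C@]23C[C@@]1(O)CC[C@H]2c1ccc(O)c(C)c1[C@@H]3Cn1cc(-c2ccc(C)cc2)nn1` carries hydrogen in place of the (4-methylphenyl)sulfonyl group but keeps 4-methylphenyl. In this assay compound 3 gives > 20000 nM, also a limit. The step that the two limits leave unreadable from compound 1 to compound 3 and the step that the two limits leave unreadable from compound 2 to compound 3 cannot be sized because of the limit of > 20000 nM in this assay, at which 3 of the 3 values shown sit. Compound 4 `C=C1C[C@]23C[C@@]1(O)CC[C@H]2c1ccc(OS(=O)(=O)c2ccc(C)cc2)c(C)c1[C@@H]3Cn1cc(-c2ccccn2)nn1` has not been measured. It differs from compound 2 by pyridin-2-yl in place of 4-methylphenyl on an aromatic carbon. Among the measured compounds shown here, the one measured step with the same exchange, from compound 1 to compound 3, runs in the opposite direction and its size is hidden by the limits, so it gives no direction. With all three measured compounds sitting at the limit, compound 4 is expected to sit there too, and the estimated step that the limit leaves unreadable from compound 2 to compound 4 is expected to be none beyond the scatter. For compound 4 the expected value in this assay is 30000 nM, with an estimated range from 10000 nM to 100000 nM.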

Compound 4, half-maximal inhibitory concentration: > 20000 nM
Compound 4 gave a limit, no number (the forecaster's own chance of this, stated with the estimate: 85%); the middle value does not contradict the limit.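

Compound 4 adds no readable step from compound 2 or from compound 1, because every compound shown stands at one limit: the limit of > 20000 nM in this assay, at which 4 of the 4 values shown sit.

The compounds shown leave open whether exchanging 4-methylphenyl and pyridin-2-yl, or hydrogen and (4-methylphenyl)sulfonyl, changes the effect on these cells at all.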